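From 3,5-dichlorophenyl to 3,4-dichlorophenyl

The source may report more compounds than this note shows. Statements on the series, on what has been measured and on what is new or still open speak of the compounds shown alone.

Within the data shown here, in a functional assay on HepG2 cells (Homo sapiens) for antiproliferative activity, read by MTT assay, with a stated time of 48 h (a lower number here means a stronger inhibitor, a higher number a weaker inhibitor), compound 1 (`N#Cc1cccc(Nc2ncnc3cc(NC(=O)/C=C/c4ccccc4)sc23)c1`) gives 15900 nM, and compound 2 (`O=C(/C=C/c1ccccc1)Nc1cc2ncnc(Nc3cc(Cl)cc(Cl)c3)c2s1`) gives 10700 nM, so compound 2 stands level with its only neighbour. Among the measured compounds shown here, the single measured step, a 1.5-fold lower number from compound 1 to compound 2 (0.17 log units; within the scatter), exchanged 3-cyanophenyl for 3,5-dichlorophenyl on the same nitrogen. Compound 3 (`O=C(/C=C/c1ccccc1)Nc1cc2ncnc(Nc3ccc(Cl)c(Cl)c3)c2s1`) carries 3,4-dichlorophenyl in place of 3,5-dichlorophenyl on a nitrogen on an aromatic ring. For the measured compounds named here, no measured step covers this exact exchange, so nothing beyond the scatter is expected in this assay. The estimated change is a 1.1-fold lower number from compound 2 to compound 3 (0.05 log units; within the scatter). For compound 3 the expected value is 9500 nM, with an estimated range of 4500 nM to 20000 nM.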

Compound 3, half-maximal inhibitory concentration: 13400 nM
For compound 3 the middle estimate is 1.4-fold (0.15 log units) below the measured one; the range from low to high includes it.
By their numbers in this assay, from the lowest: compounds 2, 3 and 1 (each within the scatter of the next).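

In this assay, the exchange on this nitrogen of 3,5-dichlorophenyl for 3,4-dichlorophenyl (a 1.3-fold higher number from compound 2 to compound 3 (0.10 log units; within the scatter)) joins the exchange of 3-cyanophenyl for 3,4-dichlorophenyl (a 1.2-fold lower number from compound 1 to compound 3 (0.07 log units; within the scatter)). All three groups now lie within the scatter of one another, so this assay does not separate two dichlorophenyl groups with the same atoms joined differently, nor either of them from 3-cyanophenyl. No measurement at hand bears on this result. On these data alone, whether a phenyl carrying an amine or a carboxylic acid on this nitrogen would give a number beyond the scatter stays open, as does the outcome of changes elsewhere on the shared core.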